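Dropping the Ortho Bromine from Compound 2

The source may report more compounds than this note shows. Statements on the series, on what has been measured and on what is new or still open speak of the compounds shown alone.

Compound 2 `Cc1cccc2cc(-c3ccccc3Br)oc12` carries a methyl on its shared core and a bromo on the attached ring. For the measured compounds named here, in an assay on cells for inhibition of Amine oxidase [flavin-containing] B (Homo sapiens), read by fluorescence and Amplex Red, with a stated time of 15 min (a higher number here means a weaker inhibitor, a lower number a stronger inhibitor), compound 2 gives 9680 nM, the highest number among the three compounds measured so far. Compound 3 `Brc1ccccc1-c1cc2ccccc2o1`, which lacks the methyl, gives 1130 nM in this assay, and compound 1 `Cc1ccc2oc(-c3cccc(Br)c3)cc2c1`, with the methyl and the bromo each placed differently, gives 250 nM.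

Going by the values given here, the only measured step between compounds that differ in a single place is an 8.6-fold lower number from compound 2 to compound 3 (0.93 log units; beyond the scatter), and that step concerns the methyl, not the bromo. Compound 4 `Cc1cccc2cc(-c3ccccc3)oc12` differs from compound 2 by hydrogen in place of bromo on an aromatic carbon. Among the compounds with values here, no measured pair differs by this change alone; compound 1 and compound 2 differ in two places at once, so their two values give no clean reading on the bromo. What the numbers do show is that compound 2 sits well above the other two, leaving room for a lower number. The expectation for compound 4 is therefore a lower number than compound 2, expressed as a 6.5-fold lower number from compound 2 to compound 4 (0.81 log units; beyond the scatter), held with wide uncertainty. Compound 4 is estimated at 1500 nM, with a range from 300 nM to 8000 nM.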

Compound 4, half-maximal inhibitory concentration: 10700 nM
Beside the measured number, compound 4's estimate is 7.1-fold (0.85 log units) below it; the measured number lies above the stated range.
By their numbers in this assay, from the lowest: compound 1; then compound 3; then compounds 2 and 4 (each within the scatter of the next).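

In this assay, hydrogen in place of bromo on this aromatic carbon gives a 1.1-fold higher number from compound 2 to compound 4 (0.04 log units; within the scatter), so with the methyl kept on the shared core, swapping the bromo for hydrogen produces no difference that can be told from the scatter. For the compounds shown here, the earlier compounds could not show this: their only single-place step concerned the methyl, and compound 1 differs from compound 2 in two places at once. No measurement on hand offers an explanation for this result.

The compounds shown leave open whether another group on this same carbon, such as an amine, a carboxylic acid or a methoxy group, would shift the number, since bromo and hydrogen are the only two compared here. From the compounds shown here alone, it also remains open whether the same swap would read the same way on a different background, such as compound 3, which lacks the methyl, or compound 1, where the methyl and the bromo are each placed differently.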